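Swapping the aryl group on the piperazine nitrogen

A few compounds are considered here, and "the series" means these few. Any claim that something is new, unique, unknown or untested is made for them only; others in the source may bear on it.

Of the compounds shown here, three of one series have been tested so far. Compound 1 `COc1ccccc1N1CCN(CC(=O)Nc2ccc(C(=O)/C=C/c3cn(Cc4ccc(Br)cc4)nn3)cc2)CC1` gives 34000 nM in a functional assay on A549 cells (Homo sapiens) for inhibition, read by MTT assay (on this read-out higher numbers stand for weaker inhibition and lower numbers for stronger inhibition), and compound 2 `CCCCCCCCn1cc(/C=C/C(=O)c2ccc(NC(=O)CN3CCN(c4ccccc4OC)CC3)cc2)nn1` gives 34000 nM. The step of no change at the digits printed from compound 1 to compound 2 (within the scatter) shows that changing the chain on that nitrogen left the read-out as it was. Compound 3 `CCCCCCCCCCn1cc(/C=C/C(=O)c2ccc(NC(=O)CN3CCN(c4ccc([N+](=O)[O-])cc4)CC3)cc2)nn1` gives 64500 nM, and its gaps to compound 1 and to compound 2 both lie within the usual scatter, so all three stand together.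

Compound 4 `CCCCCCCCCCn1cc(/C=C/C(=O)c2ccc(NC(=O)CN3CCN(c4ccccc4OC)CC3)cc2)nn1` differs from compound 3 by 2-methoxyphenyl in place of 4-nitrophenyl on an amine nitrogen in a ring. Within the data shown here, no measured pair changes this group alone; the only measured step concerns the chain, not the ring on the amine nitrogen, so it speaks to this change only indirectly. Compounds 1 and 2 carry the same 2-methoxyphenyl group as compound 4 and sit with compound 3 within the scatter. The step of a 1.5-fold lower number from compound 3 to compound 4 (0.19 log units; within the scatter) is therefore expected to stay within the scatter, with no direction. Compound 4 is estimated at 42000 nM, between 20000 nM and 85000 nM.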

Compound 4, half-maximal inhibitory concentration: 62500 nM
Beside the measured number, compound 4's estimate is 1.5-fold (0.17 log units) below it; the measured number falls inside the stated range.
By their numbers in this assay, from the lowest: compounds 1, 2, 4 and 3 (each within the scatter of the next).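

In this assay, among these compounds, this is the first pair that changes only the aryl group on the amine nitrogen in a ring: 2-methoxyphenyl in place of 4-nitrophenyl gives (a 1.0-fold lower number from compound 3 to compound 4 (0.01 log units; within the scatter)), so this exchange leaves the read-out within the scatter. At the other end of the molecule, ethyl in place of hydrogen on the saturated chain gives (a 1.8-fold higher number from compound 2 to compound 4 (0.26 log units; within the scatter)), and nonyl in place of 4-bromophenyl gives (a 1.8-fold higher number from compound 1 to compound 4 (0.26 log units; within the scatter)), so neither exchange separates these compounds. No available evidence bears on this result.

Going by these compounds, whether any change at these two places can move the number beyond the scatter remains open. A 4-aminophenyl group on the ring nitrogen, or a short propyl chain on the aromatic nitrogen, would test this.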